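The source may report more compounds than this note shows. Statements on the series, on what has been measured and on what is new or still open speak of the compounds shown alone.

- Compound 1 `Nc1ncnc2c1ncn2[C@H]1C[Se][C@@H](CO)O1`: > 100000 nM
- Compound 2 `OC[C@H]1O[C@@H](n2cnc3c(O)ncnc32)C[Se]1`: > 100000 nM
- Compound 3 `Cc1cn([C@@H]2C[Se][C@@H](CO)O2)c(=O)[nH]c1=O`: > 100000 nM

In a functional assay on Vero cells (Chlorocebus sabaeus) for cytotoxicity (a lower number here means a stronger inhibitor, a higher number a weaker inhibitor), compound 1 gives > 100000 nM, which is a limit and not a number. All three measured compounds share this result, with the limit of > 100000 nM in this assay, at which 3 of the 3 values shown sit. Among the compounds with values here, the one measured step is a step that the two limits leave unreadable from compound 1 to compound 2, and it concerns a change of group rather than of configuration. Compound 4 `Nc1ncnc2c1ncn2[C@@H]1C[Se][C@@H](CO)O1` departs from compound 1 in one respect: the two compounds have the same atoms and bonds and differ only in configuration as drawn: 1 of 2 stereo elements differ; a stereocentre at a saturated ring carbon is drawn R in compound 1 and S in compound 4. Within the data shown here, no measured step covers such a change, so the expectation rests only on (the limit of > 100000 nM in this assay, at which 3 of the 3 values shown sit). The expected step is a number no higher from compound 1 to compound 4 (the limit leaves the size open), with no direction expected beyond the scatter. Compound 4 is estimated at 100000 nM, with an expected range of 30000 nM to 200000 nM.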

Compound 4, half-maximal inhibitory concentration: > 100000 nM
Compound 4 ended at the assay's limit (the forecaster's own chance of this, stated with the estimate: 85%); the middle value sits exactly at the limit.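

In this assay compound 1 and compound 4 both end at a limit, so no step can be read between them. The compounds shown leave open whether the configuration at this saturated ring carbon affects the result at all.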